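Hydroxy to Methoxy: From Compound 1 to Compound 3

The source may report more compounds than this note shows. Statements on the series, on what has been measured and on what is new or still open speak of the compounds shown alone.

Measured compounds:
Compound 1 `O=C(Nc1ccccc1)c1cc(Br)ccc1O`: in an assay for inhibition of HSP60/HSP10 (Homo sapiens), with a stated time of 60 min (on this read-out lower numbers stand for stronger inhibition and higher numbers for weaker inhibition), compound 1 gives > 100000 nM, which is a limit of the assay rather than a number.
Compound 2 `O=C(Nc1cccc(Cl)c1)c1ccccc1O`: in this assay compound 2 gives > 100000 nM, likewise only a limit.

Compound 1 therefore stands at the limit of > 100000 nM in this assay, at which 2 of the 2 values shown sit, and nothing more definite is known of it; compound 2 shows the same picture. Compound 3 `COc1ccc(Br)cc1C(=O)Nc1ccccc1` differs from compound 1 by methyl in place of hydrogen on an oxygen on an aromatic ring. Among the measured compounds shown here, no step between measured compounds is available to gauge such a change, so the expected step from compound 1 to compound 3 is about a step that the limit leaves unreadable from compound 1 to compound 3, which is none beyond the scatter. Compound 3 is expected to give 150000 nM in this assay, with a range from 40000 nM to 600000 nM, most likely reported again only as a limit.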

Compound 3, half-maximal inhibitory concentration: > 100000 nM
Compound 3: a limit, no number; the forecaster's own chance of this, stated with the estimate: 85%; the middle value does not contradict the limit.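

Compound 1 and compound 3 both stand only at a limit, so no step can be read between them: the limit of > 100000 nM in this assay, at which 3 of the 3 values shown sit.

The compounds shown leave open whether the change from hydroxy to methoxy alters inhibition at all.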